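The source may report more compounds than this note shows. Statements on the series, on what has been measured and on what is new or still open speak of the compounds shown alone.

Measured so far in a functional assay on LNCaP cells (Homo sapiens) for antiproliferative activity; a higher number here means a weaker inhibitor, a lower number a stronger inhibitor:
- compound 1 `Cn1ncc(Cl)c1-c1cc(C(=O)N[C@@H]2CN[C@H](CCCO)C[C@H]2c2ccc(Cl)c(Cl)c2)oc1Cl`: 210 nM
- compound 2 `Cn1ncc(Cl)c1-c1cc(C(=O)N[C@@H]2CN[C@H](CC(=O)NCC(O)CO)C[C@H]2c2ccc(Cl)c(Cl)c2)oc1Cl`: 660 nM

Compound 2 holds the higher of the two numbers, which makes it the weaker inhibitor of the pair. Among the compounds with values here, the only measured step is a 3.1-fold higher number from compound 1 to compound 2 (0.50 log units; beyond the scatter). In that step, (2,3-dihydroxypropyl)carbamoyl stands in place of 2-hydroxyethyl on a saturated chain carbon bound to a saturated ring carbon.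

Compound 3 `COCC[C@@H]1C[C@@H](c2ccc(Cl)c(Cl)c2)[C@H](NC(=O)c2cc(-c3c(Cl)cnn3C)c(Cl)o2)CN1` has not yet been measured. Its difference from compound 2 is methoxymethyl in place of (2,3-dihydroxypropyl)carbamoyl on a saturated chain carbon bound to a saturated ring carbon. In words, methoxymethyl stands in place of (2,3-dihydroxypropyl)carbamoyl at that same place. The group that separates compound 2 from compound 1 therefore leaves again, although what enters is not the 2-hydroxyethyl of compound 1.

Within the data shown here, the measured step of a 3.1-fold higher number from compound 1 to compound 2 (0.50 log units; beyond the scatter) is the only guide, so a step of similar size in the opposite direction, towards a lower number, is expected in this assay. The expected step is a 2.8-fold lower number from compound 2 to compound 3 (0.44 log units; beyond the scatter). For compound 3 the estimated value is 240 nM, with an expected range of 90 nM to 600 nM.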

Compound 3, half-maximal inhibitory concentration: 250 nM
Compound 3: middle estimate off by 1.0-fold (0.02 log units), on the low side; measured number inside the range.
By their numbers in this assay, from the lowest: compounds 1 and 3 (each within the scatter of the next); then compound 2.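

Compound 3 shows that the higher number of compound 2 is not fixed by having a substituent at this place on the saturated chain carbon: in this assay, exchanging the (2,3-dihydroxypropyl)carbamoyl for methoxymethyl gives a 2.6-fold lower number from compound 2 to compound 3 (0.42 log units; beyond the scatter), which is almost the size of the earlier step in the opposite direction. The other comparison, a 1.2-fold higher number from compound 1 to compound 3 (0.08 log units; within the scatter), lies within the scatter, so the chains of compound 1 and compound 3 cannot be told apart here, even though the methoxymethyl of compound 3 has 0 hydrogen-bond donors and its terminal oxygen carries a methyl group. Nothing measured here explains why the larger group of compound 2 goes with the higher number.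

The (2,3-dihydroxypropyl)carbamoyl group is present only in compound 2 and always changes as a whole, so the carbonyl, the amide hydrogen and the two hydroxyl groups cannot be judged separately. On these data alone, how an amine, a carboxylic acid or a longer chain at this place would read in this assay also remains open.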